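Swapping Bromo for Chloro on a Sulfonyl Hydrazide

The source may report more compounds than this note shows. Statements on the series, on what has been measured and on what is new or still open speak of the compounds shown alone.

Of the compounds shown here, two with a shared core have been measured in an assay on HeLa cells for inhibition of Indoleamine 2,3-dioxygenase 1 (Homo sapiens), read by spectrophotometry, with a stated time of 24 h; a lower number here means that less compound is needed, a higher number that more compound is needed for the effect. Compound 1, `CC(=O)Nc1ccc(S(=O)(=O)NNc2ccc(Cl)cc2)cc1`, gives 142 nM. Compound 2, `CC(=O)Nc1ccc(S(=O)(=O)NNc2ccc(Br)c(F)c2)cc1`, gives 187 nM; its number and that of compound 1 lie within the usual scatter of each other, so neither stands apart. Compound 3, `CC(=O)Nc1ccc(S(=O)(=O)NNc2ccc(Cl)c(F)c2)cc1`, has not yet been measured. Relative to compound 2 the change is chloro in place of bromo on an aromatic carbon. For the measured compounds named here, with no comparable step among the measured pair, a step from compound 2 to compound 3 of a 1.2-fold lower number from compound 2 to compound 3 (0.07 log units; within the scatter) is expected, hardly beyond the scatter in either direction. Compound 3 is therefore estimated at 160 nM, within a range of 80 nM to 320 nM.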

Compound 3, half-maximal effective concentration: 84 nM
Compound 3: the middle estimate sits 1.9-fold (0.28 log units) above what was measured, within the range that was stated.
By their numbers in this assay, from the lowest: compounds 3, 1 and 2 (each within the scatter of the next, the first and the last beyond it).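

At this position, ortho to a fluoro group, chloro in place of bromo gives a 2.2-fold lower number from compound 2 to compound 3 (0.35 log units; beyond the scatter), so the choice of halogen here makes a modest but readable difference. Fluoro in place of hydrogen on an aromatic carbon, with the chloro kept, gives a 1.7-fold lower number from compound 1 to compound 3 (0.23 log units; within the scatter), so that change cannot be told apart from no change. No measurement shown explains the step from bromo to chloro. As far as these compounds go, how a methyl, methoxy or amino group at this position would compare with chloro stays open, as does whether the same step would appear without the fluoro group.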